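The source may report more compounds than this note shows. Statements on the series, on what has been measured and on what is new or still open speak of the compounds shown alone.

Measured so far:
- compound 1 `CC(C)n1nc2c(c1-c1ccccc1)CCNCC2`: 28 nM in an assay on HEK293 cells for displacement of a labelled ligand from 5-hydroxytryptamine receptor 7 (Rattus norvegicus), read by radioligand binding; a lower number here means a stronger inhibitor, a higher number a weaker inhibitor
- compound 2 `CNc1ccc(-c2c3c(nn2C(C)C)CCNCC3)cc1`: 40 nM in this assay

Compound 2 gives the highest of the two numbers, but its nearest neighbour is compound 1, and the step of a 1.4-fold higher number from compound 1 to compound 2 (0.15 log units; within the scatter) stays within the scatter, so the two compounds cannot be told apart on these numbers. The unmeasured compound 3 `CC(C)n1nc2c(c1-c1ccc(OC(F)(F)F)cc1)CCNCC2` keeps the shared core of compound 2 and changes only one place: trifluoromethoxy in place of methylamino on an aromatic carbon, on an aromatic carbon of a six-membered aromatic ring of carbon only, para to a large group. Going by the values given here, only one measured step touches this place, the step of a 1.4-fold higher number from compound 1 to compound 2 (0.15 log units; within the scatter), which put methylamino where hydrogen had been and did not move the number beyond the scatter. Hydrogen and methylamino at this place thus gave much the same result, and there is no measured trifluoromethoxy to compare with. The expected step of a 1.1-fold lower number from compound 2 to compound 3 (0.06 log units; within the scatter) is therefore small, without a clear direction. For compound 3 the estimate in this assay is 35 nM, with a range from 12 nM to 100 nM.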

Compound 3, inhibition constant: 5000 nM
Compound 3: the middle estimate sits 140-fold (2.15 log units) below what was measured; the whole stated range lies below it.
By their numbers in this assay, from the lowest: compounds 1 and 2 (each within the scatter of the next); then compound 3.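

In this assay, this position on the aromatic ring proves far from indifferent: trifluoromethoxy gives a 130-fold higher number from compound 2 to compound 3 (2.10 log units; beyond the scatter) when it replaces methylamino and a 180-fold higher number from compound 1 to compound 3 (2.25 log units; beyond the scatter) when it replaces hydrogen. Hydrogen and methylamino had given results within the scatter of each other, so the earlier pair showed only that these two groups are interchangeable here, and compound 3, now clearly the weakest of the three, shows that this does not extend to every group. Trifluoromethoxy brings 5 heavy atoms and 0 hydrogen-bond donors where methylamino has 2 heavy atoms and 1 hydrogen-bond donor, but nothing shown gives a measured reason for the large change.

With a single group showing this drop, the compounds shown cannot separate the part played by its oxygen from that of its fluorines or its overall size. A methoxy group would keep the oxygen without the fluorines, and a trifluoromethyl group would keep the fluorines without the oxygen, so either could help to show which part of trifluoromethoxy goes with the higher number.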